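The compounds below may be only part of what the source reports. "The series", "measured", "known", "first", "only" and "open" are said of these compounds alone.

Compound 1 `COC(=O)/C=C/c1cccc(N(Cc2ccc(-c3ccc(F)c(Cl)c3)cc2)C(=O)C2CCCCC2)c1` is the reference point of this small set. For the measured compounds named here, in an assay on isolated protein with Bile acid receptor (Homo sapiens) as the target (a lower number here means that less compound is needed, a higher number that more compound is needed for the effect), compound 1 gives 66 nM, and this is the only plain number among the values shown. Going by the values given here, compound 2 `COC(=O)/C=C/c1cccc(N(Cc2ccc(/C=C/C(=O)OC(C)(C)C)cc2O)C(=O)C2CCCCC2)c1` was also tested, but in this assay compound 2 gives > 1000 nM, which is a limit of the assay and not a number, so it offers no step to compare against; it is the limit of > 1000 nM in this assay, at which 1 of the 2 values shown sits. Among the compounds with values here, compound 1 therefore stands alone as the one compound with a measured value, and everything expected of compound 3 rests on it.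

Compound 3 `COC(=O)/C=C/c1cccc(N(Cc2ccc(/C=C/c3ccc(F)cc3)cc2)C(=O)C2CCCCC2)c1` shares the core of compound 1 and differs from it in one place: 2-(4-fluorophenyl)ethenyl in place of 3-chloro-4-fluorophenyl on an aromatic carbon. Within the data shown here, no measured pair in this set shows what such an exchange does, so the size of the step can only be estimated. Both groups carry a single aromatic ring of carbon only and one fluorine, and the change is expected to move the value in this assay only modestly, toward a slightly weaker compound 3, a step of a 1.8-fold higher number from compound 1 to compound 3 (0.26 log units; within the scatter). Compound 3 is expected at about 120 nM, within a range from 40 nM to 400 nM.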

Compound 3, half-maximal effective concentration: 185 nM
Compound 3: the middle estimate sits 1.5-fold (0.19 log units) below what was measured, and the stated range covers the measured number.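

For the compounds shown here, the exchange of 3-chloro-4-fluorophenyl for 2-(4-fluorophenyl)ethenyl gives the first measured step at this place, on an aromatic carbon para to a large group: in this assay it brings a 2.8-fold higher number from compound 1 to compound 3 (0.45 log units; beyond the scatter). The step lies beyond the usual scatter but remains modest, so this position responds to the change without losing a measurable value, and compound 3 still gives a plain number with a double bond outside the aromatic ring in the group. Nothing measured here bears on the cause of this step.

The compounds shown do not separate the loss of the chlorine from the arrival of the double bond, as neither a plain 4-fluorophenyl group nor a saturated two-carbon link to the ring appears among them at this place. Going by these compounds, it also remains open how this position would respond to an amine, a carboxylic acid or a longer chain, and whether the fluorine on the ring of 2-(4-fluorophenyl)ethenyl contributes to the value of compound 3.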